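Bromo for methoxy on a compound at the limit

The compounds below may be only part of what the source reports. "The series", "measured", "known", "first", "only" and "open" are said of these compounds alone.

In a functional assay on PC-3 cells (Homo sapiens) for antiproliferative activity, read by MTT assay, with a stated time of 48 h (on this read-out higher numbers stand for weaker inhibition and lower numbers for stronger inhibition), compound 2 (`COc1ccc(CN(C(=O)CSc2nc3ccccc3s2)c2cc(OC)c(OC)c(OC)c2)cc1OC`) reads > 80000 nM, which is a limit and not a number, and it stands at the limit of > 80000 nM in this assay, at which 1 of the 2 values shown sits, on this scale. Compound 3 (`COc1ccc(CN(C(=O)CSc2nc3ccccc3s2)c2cc(OC)c(OC)c(OC)c2)cc1Br`) differs from it by bromo in place of methoxy on an aromatic carbon, with bromo in place of methoxy on an aromatic carbon, ortho to a methoxy group. Among the measured compounds shown here, one measured step bears on this change. On that same carbon compound 1 (`COc1ccc(CN(C(=O)CSc2nc3ccccc3s2)c2cc(OC)c(OC)c(OC)c2)cc1N=[N+]=[N-]`) carries azido and gives 14400 nM in this assay as its reading. That step, an at least 5.5-fold higher number from compound 1 to compound 2 (0.74 log units; beyond the scatter), put methoxy in place of azido, so removing methoxy from compound 2 is expected to give a step of similar size toward lower numbers. The estimated move is an at least 3.2-fold lower number from compound 2 to compound 3 (0.50 log units; beyond the scatter), resting on that single step. In this assay compound 3 is estimated at 25000 nM, with an expected range from 8000 nM to 75000 nM around that figure.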

Compound 3, half-maximal inhibitory concentration: 16000 nM
For compound 3 the middle estimate is 1.6-fold (0.19 log units) above the measured one; measured number inside the range.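

Among the compounds shown here, on this aromatic carbon, ortho to a methoxy group, methoxy is no longer the only group with a known outcome, and bromo also brings a measurable reading in this assay: an at least 5.0-fold lower number from compound 2 to compound 3 (0.69 log units; beyond the scatter). Bromo and azido, two quite different groups, are not separated by this read-out, a 1.1-fold higher number from compound 1 to compound 3 (0.05 log units; within the scatter). Among the three compounds, compound 2 is the only one with methoxy on this carbon and the only one whose reading is a limit and not a number: the limit of > 80000 nM in this assay, at which 1 of the 3 values shown sits.

The compounds shown leave open whether an amine, a hydroxyl group or plain hydrogen on this carbon would read like bromo and azido or like methoxy. They also leave open whether the step from methoxy to bromo would hold with the other parts of the core changed.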